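Exchanging 3,5-dimethoxyphenyl for 4-fluorophenyl on compound 3

This account rests on a few compounds, and the source may have more. Where it says the series, first, only, none or still open, it means among the compounds named here.

Compound 1 `COc1cc(Nc2nc3ccccc3nc2S(=O)(=O)c2ccccc2)cc(OC)c1`: 70 nM
Compound 2 `O=S(=O)(c1ccccc1)c1nc2ccccc2nc1Nc1ccc(F)cc1`: > 50000 nM (a limit)
Compound 3 `COc1ccc(S(=O)(=O)c2nc3ccccc3nc2Nc2cc(OC)cc(OC)c2)cc1`: 12700 nM

All three results come from a functional assay on A549 cells (Homo sapiens) for cytotoxicity, read by MTT assay, with a stated time of 72 h; on this read-out higher numbers stand for weaker inhibition and lower numbers for stronger inhibition. For compound 2 the assay gives only a limit, > 50000 nM, and not a number. Of the two true numbers, the higher belongs to compound 3, at 12700 nM, which marks the weaker inhibition. With methoxy in place of hydrogen on an aromatic carbon, the shift is a 180-fold higher number from compound 1 to compound 3 (2.26 log units; beyond the scatter).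

Compound 4 `COc1ccc(S(=O)(=O)c2nc3ccccc3nc2Nc2ccc(F)cc2)cc1` has not yet been measured. It differs from compound 3 in one place: 4-fluorophenyl in place of 3,5-dimethoxyphenyl on a nitrogen on an aromatic ring. In words, this is 4-fluorophenyl in place of 3,5-dimethoxyphenyl on a nitrogen on an aromatic ring.

Within the data shown here, the one measured step with this same exchange is an at least 710-fold higher number from compound 1 to compound 2 (2.85 log units; beyond the scatter). On these data alone, it is large, but it ends at a limit, so its true size remains unknown. It was also measured without the methoxy, so it may not carry over in full. A rise in this assay is therefore expected, and compound 4 may well return only a limit. The expected shift is a 3.9-fold higher number from compound 3 to compound 4 (0.60 log units; beyond the scatter). For compound 4 the estimated value is 50000 nM, within an expected range of 15000 nM to 150000 nM.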

Compound 4, half-maximal inhibitory concentration: 1240 nM
Estimate against measurement, compound 4: 40-fold (1.61 log units) above; measured number outside the range, below it.
By their numbers in this assay, from the lowest: compound 1; then compound 4; then compound 3. At a limit, above all of these: compound 2.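

This result shows that the two places do not act independently in this assay. On these data alone, with the methoxy present, the exchange of 3,5-dimethoxyphenyl for 4-fluorophenyl brings a 10-fold lower number from compound 3 to compound 4 (1.01 log units; beyond the scatter), the opposite direction to the step without the methoxy: the same change on two cores in this assay, an at least 710-fold higher number (2.85 log units; beyond the scatter) from compound 1 to compound 2 and a 10-fold lower number (1.01 log units; beyond the scatter) from compound 3 to compound 4, at least 7300-fold (3.86 log units) apart, beyond the scatter of two such steps Adding the methoxy likewise changes direction with the group on the nitrogen, bringing an at least 40-fold lower number from compound 2 to compound 4 (1.60 log units; beyond the scatter) when that group is 4-fluorophenyl, whereas it raised the number when that group was 3,5-dimethoxyphenyl: the same change on two cores in this assay, a 180-fold higher number (2.26 log units; beyond the scatter) from compound 1 to compound 3 and an at least 40-fold lower number (1.60 log units; beyond the scatter) from compound 2 to compound 4, at least 7300-fold (3.86 log units) apart, beyond the scatter of two such steps Compound 2 gives > 50000 nM, which is a limit and not a number, so the true size of both gaps remains unknown.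

The compounds shown leave open whether this reversal is special to methoxy and 4-fluorophenyl, or whether it also appears with an ethoxy group or an amine in place of the methoxy, or with a 4-chlorophenyl group on the nitrogen. They also cannot say why the two places are linked, and four compounds forming a single square of changes give no way to test how widely the link holds.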